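The compounds below may be only part of what the source reports. "The series", "measured", "known", "first", "only" and "open" are said of these compounds alone.

Three compounds of the series have been measured in an assay on isolated protein for inhibition of protein deacetylase HDAC6 (Homo sapiens), read by fluorescence, with a stated time of 1 h, tested at 100 nM; on this read-out lower numbers stand for less inhibition and higher numbers for more inhibition at the one concentration tested (going by the name of the read-out):

compound 1 `O=C(CCc1ccc(OCc2nc(C3CCN(Cc4ccccc4)CC3)no2)cc1)NO` gives 22%
compound 2 `Cc1ccc(CN2CCC(c3noc(COc4ccc(CCC(=O)NO)cc4)n3)CC2)cc1` gives 28%
compound 3 `CN(Cc1nc(C2CCN(Cc3ccccc3)CC2)no1)c1ncc(/C=C/C(=O)NO)cn1` gives 55%

Compound 2 differs from compound 1 only by methyl in place of hydrogen on an aromatic carbon. In this assay this gave the step of a number 6 percentage points higher from compound 1 to compound 2 (within the scatter), so the two readings are not separated by the assay. Compound 3 sits highest of the three, with both other compounds beyond the scatter below it; how its core differs from the core of compound 1 is not broken down here.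

Compound 4 `Cc1ccc(CN2CCC(c3noc(CN(C)c4ncc(/C=C/C(=O)NO)cn4)n3)CC2)cc1` has not yet been measured in this assay. It differs from compound 3 by methyl in place of hydrogen on an aromatic carbon, the same change, at the same kind of place, as from compound 1 to compound 2. For the measured compounds named here, the single precedent for this change was a number 6 percentage points higher from compound 1 to compound 2 (within the scatter), a step that does not rise above the scatter. Going by the values given here, on that basis the step expected for the same change on the core of compound 3 is estimated as a number 5 percentage points higher from compound 3 to compound 4 (within the scatter), with the earlier step as its only guide. Compound 4 is therefore expected to read 60% in this assay. Allowing for the scatter and the single precedent, the estimate for compound 4 is expected to lie between 45% and 75%.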

Compound 4, a percentage reported as inhibition, at one concentration (the size of the read-out at that concentration, not a potency): 60%
The estimate for compound 4 equals the measured number at the digits printed; low and high end bracket the measured number.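

In this assay, benzyl to 4-methylbenzyl on the core of compound 3 gives a number 5 percentage points higher from compound 3 to compound 4 (within the scatter), so on this core too the change is not separated from the scatter. Set beside the earlier step, the two results agree: the same change on two cores in this assay, a number 6 percentage points higher (within the scatter) from compound 1 to compound 2 and a number 5 percentage points higher (within the scatter) from compound 3 to compound 4, 1 percentage points apart, within the scatter of two such steps This shows that the change carries between these two cores without a step that rises above the scatter, but it does not show that the methyl has any real effect on the reading, and two pairs say nothing about how it behaves on any other core of the series.

Still open, on these data alone, is whether a different group on the same aromatic carbon, such as ethyl, methoxy, chlorine or a carboxylic acid, would give a step that rises above the scatter. Also open, as far as these compounds go, is whether the methyl would stay within the scatter at another place on that ring, since both pairs carry it para to a large group.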